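This account rests on a few compounds, and the source may have more. Where it says the series, first, only, none or still open, it means among the compounds named here.

The measured compounds:
compound 1, `COc1ccc(NC(=O)NCCNS(=O)(=O)c2ccc(-c3ccccc3OCc3ccccc3)s2)cc1`, gives > 50000 nM in a functional assay on HeLa cells (Homo sapiens) for inhibition, read by CCK-8 assay, with a stated time of 48 h (a higher number here means a weaker inhibitor, a lower number a stronger inhibitor), a limit of the assay.
compound 2, `O=S(=O)(NCCNC(=S)Nc1cccc(Cl)c1)c1ccc(-c2ccccc2OCc2ccccc2)s1`, gives 8400 nM in this assay.
compound 3, `COc1ccc(NC(=O)NCCNS(=O)(=O)c2ccc(-c3ccccc3Oc3ccc([N+](=O)[O-])cc3)s2)cc1`, gives > 20000 nM in this assay, also a limit.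

Compound 2 differs from compound 1 by a group of 10 heavy atoms (7 carbon, 1 nitrogen, 1 sulfur, 1 chlorine; one six-membered aromatic ring of carbon only) in place of a group of 11 heavy atoms (8 carbon, 1 nitrogen, 2 oxygen; one six-membered aromatic ring of carbon only), on an amine nitrogen. The step is an at least 5.9-fold lower number from compound 1 to compound 2 (0.77 log units; beyond the scatter); its full size is hidden, compound 1 sitting at the limit of > 50000 nM in this assay, at which 1 of the 3 values shown sits. Compound 3 differs from compound 1 by 4-nitrophenyl in place of benzyl on an oxygen on an aromatic ring, and here a step that the two limits leave unreadable from compound 1 to compound 3, with compound 3 at the limit of > 20000 nM in this assay, at which 1 of the 3 values shown sits.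

Compound 4, `O=[N+]([O-])c1ccc(Oc2ccccc2-c2ccc(S(=O)(=O)NCCNC(=S)Nc3cccc(Cl)c3)s2)cc1`, is not yet measured. Its difference from compound 3 is a group of 10 heavy atoms (7 carbon, 1 nitrogen, 1 sulfur, 1 chlorine; one six-membered aromatic ring of carbon only) in place of a group of 11 heavy atoms (8 carbon, 1 nitrogen, 2 oxygen; one six-membered aromatic ring of carbon only), on an amine nitrogen, the same change as before and on the same place, an amine nitrogen whose other neighbours are saturated chain carbon. Compound 4 is expected to give an at least 2.8-fold lower number from compound 3 to compound 4 (0.45 log units; beyond the scatter) in this assay, an expectation that rests on an at least 5.9-fold lower number from compound 1 to compound 2 (0.77 log units; beyond the scatter). The estimate for compound 4 is 7000 nM, between 2000 nM and 25000 nM.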

Compound 4, half-maximal inhibitory concentration: 4600 nM
Estimate against measurement, compound 4: 1.5-fold (0.18 log units) above, within the range that was stated.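

In this assay the replacement of (4-methoxyphenyl)carbamoyl on the amine nitrogen carried over to a second core, in the same direction, with an at least 4.3-fold lower number from compound 3 to compound 4 (0.63 log units; beyond the scatter), and the two steps can be set side by side: the same change on two cores in this assay, an at least 5.9-fold lower number (0.77 log units; beyond the scatter) from compound 1 to compound 2 and an at least 4.3-fold lower number (0.63 log units; beyond the scatter) from compound 3 to compound 4; the limit leaves it open whether they differ

Compound 3 is only a limit of the assay at > 20000 nM, so the full size of this step stays hidden, and the same holds for the earlier step, which starts from a limit too.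

With the new group in place, the other change gives a 1.8-fold lower number from compound 2 to compound 4 (0.26 log units; within the scatter), while the step from compound 1 to compound 3 cannot be read.

The compounds shown leave open which part of the entering group carries the step, the sulfur or the chlorine. They also leave open whether it would hold with a methyl ether in place of benzyl or with a longer chain on the amine nitrogen.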